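Reducing the aldehyde: compound 4 against compound 1

The source may hold more compounds than are shown below. What is called first, only, known or untested is meant among the compounds shown, and "the series" means these compounds.

Of the compounds shown here, three sharing one core have been tested in an assay on isolated protein for inhibition of Amine oxidase [flavin-containing] A (Homo sapiens), read by fluorescence and spectrophotometry, with a stated time of 20 min; a lower number here means a stronger inhibitor, a higher number a weaker inhibitor. Compound 1 `COn1c(-c2ccccc2)c(C=O)c2cc(C#N)c(C#N)cc21` gives 522 nM, the highest of the three numbers. Compound 2 `COn1c(-c2ccc(C)cc2)c(C=O)c2cc(C#N)c(C#N)cc21` gives 405 nM, and the step of a 1.3-fold lower number from compound 1 to compound 2 (0.11 log units; within the scatter) lies within the scatter. Compound 3 `COc1ccc(-c2c(C=O)c3cc(C#N)c(C#N)cc3n2OC)cc1` gives 147 nM, and the steps of a 3.6-fold lower number from compound 1 to compound 3 (0.55 log units; beyond the scatter) and a 2.8-fold lower number from compound 2 to compound 3 (0.44 log units; beyond the scatter) are both modest but beyond the scatter.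

Compound 4 `COn1c(-c2ccccc2)c(CO)c2cc(C#N)c(C#N)cc21` has not yet been measured. It differs from compound 1 in one place: hydroxymethyl in place of formyl on an aromatic carbon. Among the compounds with values here, every measured step so far changes the group on the phenyl ring and leaves the formyl untouched, so none of them bears directly on this change; the formyl is kept in all three measured compounds. Within the data shown here, what is known is only that changes at the phenyl ring moved the number by modest amounts at most. Among the measured compounds shown here, with no step touching the formyl, the direction of the expected change rests on nothing measured, and a wide range is the honest answer.

For compound 4 the estimate in this assay is 800 nM, expected to lie between 200 nM and 3200 nM, meaning an expected step of a 1.5-fold higher number from compound 1 to compound 4 (0.19 log units; within the scatter).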

Compound 4, half-maximal inhibitory concentration: 4990 nM
Compound 4: middle estimate off by 6.2-fold (0.80 log units), on the low side; measured number outside the range, above it.
By their numbers in this assay, from the lowest: compound 3; then compounds 2 and 1 (each within the scatter of the next); then compound 4.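

Within the data shown here, the formyl position matters far more than the earlier compounds could show: in this assay, replacing formyl with hydroxymethyl gives a 9.6-fold higher number from compound 1 to compound 4 (0.98 log units; beyond the scatter), a larger move than the biggest step on the phenyl ring, a 3.6-fold lower number from compound 1 to compound 3 (0.55 log units; beyond the scatter). Formyl and hydroxymethyl carry the same heavy atoms, one carbon and one oxygen, so this shift comes from a change that leaves the atom count alone, with a double bond leaving and a hydrogen-bond donor entering. No measurement here explains why the number rises so much.

The compounds shown cannot separate the loss of the double bond from the gain of the donor, and a methoxymethyl group or a carboxylic acid at this position would help pull those two changes apart, while an aminomethyl group would test a different kind of donor. They also leave open whether the methyl and methoxy groups on the phenyl ring would move the number in the same way if hydroxymethyl stood in place of formyl.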